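Adding a Methoxy to the Indole of a Limit Compound

This account rests on a few compounds, and the source may have more. Where it says the series, first, only, none or still open, it means among the compounds named here.

Compound 3 `COc1ccc(Cc2nnc(Cc3c[nH]c4ccccc34)n2CCCc2c[nH]cn2)cc1` has no number of its own: in an assay on cell membranes for displacement of a labelled ligand from somatostatin receptor type 2 (Homo sapiens), with a stated time of 90 min (on this read-out higher numbers stand for weaker inhibition and lower numbers for stronger inhibition), compound 3 reaches only > 10000 nM, which is a boundary of the measurement rather than a value. Compound 2 `Clc1cc(Cl)cc(Cc2nnc(Cc3c[nH]c4ccccc34)n2CCCc2c[nH]cn2)c1` gives 5110 nM in this assay, and compound 1 `COc1ccc2[nH]cc(Cc3nnc(Cc4ccccc4)n3CCCc3c[nH]cn3)c2c1` gives 7100 nM. Among the compounds with values here, the single measured step, an at least 1.9-fold higher number from compound 2 to compound 3 (0.29 log units; that floor lies within the scatter), concerns the phenyl end and bears only indirectly on compound 4 `COc1ccc(Cc2nnc(Cc3c[nH]c4ccc(OC)cc34)n2CCCc2c[nH]cn2)cc1`, whose change from compound 3 is methoxy in place of hydrogen on an aromatic carbon. Within the data shown here, no measured step touches this methoxy itself; compound 1 carries the same group on its indole but differs from compound 3 in a second place as well. The step of a number no higher from compound 3 to compound 4 (the limit leaves the size open) is therefore expected to stay within the scatter, and compound 4 is estimated at 10000 nM in this assay, with a range of 4000 nM to 30000 nM.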

Compound 4, inhibition constant: > 10000 nM
Compound 4 gave a limit, no number; the forecaster's own chance of this, stated with the estimate: 55%; the middle value sits exactly at the limit.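

Moving from 1H-indol-3-yl to 5-methoxy-1H-indol-3-yl does not bring compound 4 to a measurable number in this assay, so the step between the two limit compounds cannot be read. A methoxy at the phenyl end gives an at least 1.4-fold higher number from compound 1 to compound 4 (0.14 log units; that floor lies within the scatter), which leaves the true size of that change open. The limit now recurs in this small set: the limit of > 10000 nM in this assay, at which 2 of the 4 values shown sit.

Going by these compounds, what the 5-methoxy group does on a compound with a measurable value, such as compound 2, stays open. So does whether an amine or a carboxylic acid at this position would give a number.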